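The source may hold more compounds than are shown below. What is called first, only, known or untested is meant among the compounds shown, and "the series" means these compounds.

For the measured compounds named here, in an assay on HeLa cells for binding affinity to 5-hydroxytryptamine receptor 6 (Homo sapiens) (a lower number here means a stronger inhibitor, a higher number a weaker inhibitor), compound 2, with the structure `Cc1ccc(S(=O)(=O)c2cn(CCN(C)C)c3ccccc23)cc1`, gives 57 nM, the higher of the two numbers measured so far. Compound 1, with the structure `CNCCn1cc(S(=O)(=O)c2ccccc2)c2ccccc21`, gives 15.5 nM in this assay, and the gap between the two compounds lies beyond the usual scatter, so compound 2 is the weaker binder of the pair. Compound 3, with the structure `CN(C)CCn1cc(S(=O)(=O)c2cccc(F)c2)c2ccccc21`, has not yet been measured. It differs from compound 2 in one place: 3-fluorophenyl in place of 4-methylphenyl on a sulfonyl sulfur. No measured pair among these compounds shows what this exchange does on its own, so the expectation rests only on the exchange itself. A modest step toward a lower number is expected, one that may stay within the scatter, and it is estimated as a 1.6-fold lower number from compound 2 to compound 3 (0.21 log units; within the scatter). The value expected for compound 3 in this assay is 35 nM, with a range from 12 nM to 100 nM.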

Compound 3, inhibition constant: 13 nM
Estimate against measurement, compound 3: 2.7-fold (0.43 log units) above; low and high end bracket the measured number.
By their numbers in this assay, from the lowest: compounds 3 and 1 (each within the scatter of the next); then compound 2.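

For the compounds shown here, on the sulfonyl sulfur, 3-fluorophenyl in place of 4-methylphenyl is the first single exchange that can be read on its own, and in this assay it gives a 4.4-fold lower number from compound 2 to compound 3 (0.64 log units; beyond the scatter), so the group at this place can change the number without any other change to the molecule. The two groups have the same count of heavy atoms, and neither has a hydrogen-bond donor, a hydrogen-bond acceptor or a net charge, so these counts do not separate them. Nothing available explains why the number falls.

Going by these compounds, the exchange removes a methyl group and adds a fluorine at a different ring place in one step, so the share of each remains open. A 4-fluorophenyl or 3-methylphenyl group on the sulfonyl sulfur could separate those two parts.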